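A Tetrazole in Place of a Triazole: Expected Cytotoxicity

The compounds below may be only part of what the source reports. "The series", "measured", "known", "first", "only" and "open" are said of these compounds alone.

Of the compounds shown here, two have been measured in a functional assay on C6 cells (Rattus norvegicus) for cytotoxicity, read by MTT assay, with a stated time of 24 h, tested at 200 ug/mL; a higher number here means a weaker effect of the compound at the concentration tested, a lower number a stronger effect. Compound 1 `Cc1ccc(-c2cs/c(=N/NC(=O)CSc3nnnn3C)n2-c2ccccc2)cc1` gives 39.7%. Compound 2 `Cn1cnnc1SCC(=O)N/N=c1/scc(-c2ccc(C#N)cc2)n1-c1ccccc1` gives 52.6%, the higher of the two numbers, and its gap to compound 1 lies beyond the usual scatter. Compound 3 `Cn1nnnc1SCC(=O)N/N=c1/scc(-c2ccc(C#N)cc2)n1-c1ccccc1` has not yet been measured. It differs from compound 2 in one place (1-methyl-1H-tetrazol-5-yl in place of 4-methyl-4H-1,2,4-triazol-3-yl on a sulfur). Within the data shown here, no measured pair isolates this change. The step of a number 4.6 percentage points lower from compound 2 to compound 3 (within the scatter) is expected to stay within the scatter, with no settled direction. Compound 3 is therefore expected to give 48% in this assay, within a range from 30% to 68%.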

Compound 3, a percentage reported as activity, at one concentration (the size of the read-out at that concentration, not a potency): 28.6%
Beside the measured number, compound 3's estimate is 19.4 percentage points above it; the measured number lies below the stated range.
By their numbers in this assay, from the lowest: compound 3; then compound 1; then compound 2.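

In this assay the ring on the sulfur is not a silent place: the step of a number 24 percentage points lower from compound 2 to compound 3 (beyond the scatter) shows that 1-methyl-1H-tetrazol-5-yl in place of 4-methyl-4H-1,2,4-triazol-3-yl strengthens the effect at the concentration tested. With the tetrazole held, cyano in place of methyl on an aromatic carbon gives the step of a number 11.1 percentage points lower from compound 1 to compound 3 (beyond the scatter) and leaves compound 3 with the strongest effect of the three. Nothing shown here explains either step. Going by these compounds, whether the cyano step holds with the triazole stays open. So does whether an amine or a carboxylic acid in place of cyano would change the number.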